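The source may report more compounds than this note shows. Statements on the series, on what has been measured and on what is new or still open speak of the compounds shown alone.

Measured in a functional assay on MDA-MB-231 cells (Homo sapiens) for antiproliferative activity, read by CCK-8 assay, with a stated time of 72 h; a higher number here means a weaker inhibitor, a lower number a stronger inhibitor:
Compound 1 `Cc1cc(Nc2cc(N3CCN(C)CC3)nc(Nc3ccc([N+](=O)[O-])cc3)n2)n[nH]1`: 84.4 nM
Compound 2 `COc1cccc(Nc2nc(Nc3cc(C)[nH]n3)cc(N3CCN(C)CC3)n2)c1`: 240 nM

Compound 2, at 240 nM, has the higher of the two numbers in this assay. Compound 3 `COc1ccc(Nc2nc(Nc3cc(C)[nH]n3)cc(N3CCN(C)CC3)n2)cc1` differs from it in one place: 4-methoxyphenyl in place of 3-methoxyphenyl on a nitrogen on an aromatic ring. Among the compounds with values here, only one measured step bears on that place, the modest 2.8-fold higher number from compound 1 to compound 2 (0.45 log units; beyond the scatter). That step does not compare the two methoxyphenyl groups, so it gives no firm direction, and no change beyond the scatter is expected. The expected step is a 1.2-fold lower number from compound 2 to compound 3 (0.08 log units; within the scatter). For compound 3 the estimated value is 200 nM, with an expected range from 80 nM to 500 nM.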

Compound 3, half-maximal inhibitory concentration: 243 nM
Estimate against measurement, compound 3: 1.2-fold (0.08 log units) below; measured number inside the range.
By their numbers in this assay, from the lowest: compound 1; then compounds 2 and 3 (each within the scatter of the next).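

In this assay, 4-methoxyphenyl in place of 3-methoxyphenyl gives a 1.0-fold higher number from compound 2 to compound 3 (0.01 log units; within the scatter), so the two methoxyphenyl groups are not told apart at this nitrogen. Methoxy in place of nitro on an aromatic carbon gives a 2.9-fold higher number from compound 1 to compound 3 (0.46 log units; beyond the scatter), so the gap to compound 1 holds for both methoxyphenyl groups. Nothing available explains either result. From the compounds shown here alone, whether an amine, a chlorine or a nitrile on the same phenyl ring would read like compound 1 or like compound 2 and compound 3 remains open.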